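A few compounds are considered here, and "the series" means these few. Any claim that something is new, unique, unknown or untested is made for them only; others in the source may bear on it.

Measured compounds:
compound 1, `COc1ccc(-c2cc3[nH]nc(N)c3c(=O)[nH]2)cc1`, 62%
compound 2, `CN1CCN(c2ccc(-c3cc4[nH]nc(N)c4c(=O)[nH]3)cc2)CC1`, 83%
compound 3, `COc1ccc(-c2cc3nn(-c4ccccc4)c(N)c3c(=O)[nH]2)cc1`, 6%

All three were tested in an assay on isolated protein for inhibition of ribosomal protein S6 kinase alpha-5 (Homo sapiens), read by mobility shift assay, tested at 30 uM; a lower number here means less inhibition, a higher number more inhibition at the concentration tested (going by the name of the read-out). Compound 1 and compound 2 share a core and differ by 4-methylpiperazin-1-yl in place of methoxy on an aromatic carbon; this step gave a number 21 percentage points higher from compound 1 to compound 2 (beyond the scatter). Compound 3 carries a different core; how its core differs from that of compound 1 is not broken down here, and in this assay compound 3 gives 6%, the lowest of the three numbers.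

Compound 4, `CN1CCN(c2ccc(-c3cc4nn(-c5ccccc5)c(N)c4c(=O)[nH]3)cc2)CC1`, is not yet measured. It differs from compound 3 by 4-methylpiperazin-1-yl in place of methoxy on an aromatic carbon, the same change as from compound 1 to compound 2, at the same place. Resting on a number 21 percentage points higher from compound 1 to compound 2 (beyond the scatter) and on the low starting point of compound 3 at 6%, a step of a number 14 percentage points higher from compound 3 to compound 4 (beyond the scatter) is expected. Compound 4 is thus estimated at 20%, between 3% and 45%.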

Compound 4, a percentage reported as inhibition, at one concentration (the size of the read-out at that concentration, not a potency): 12%
Estimate against measurement, compound 4: 8 percentage points above; the range from low to high includes it.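

In this assay, placing 4-methylpiperazin-1-yl in position of methoxy on the core of compound 3 gave a number 6 percentage points higher from compound 3 to compound 4 (within the scatter) and so did not repeat the step seen on the core of compound 1. The two steps differ: the same change on two cores in this assay, a number 21 percentage points higher (beyond the scatter) from compound 1 to compound 2 and a number 6 percentage points higher (within the scatter) from compound 3 to compound 4, 15 percentage points apart, beyond the scatter of two such steps. This shows that the size of the step did not carry over unchanged between these two cores, but it does not show why, and two cores give no rule for any other core.

The compounds shown leave open whether an open-chain amine such as dimethylamino, or a carboxylic acid, on the same aromatic carbon would behave alike on both cores. They also leave open how the change would fare with methyl in place of the phenyl of compound 3.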